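Phenylsulfonyl for (2-nitrophenyl)carbonyl on the amine nitrogen

A few compounds are considered here, and "the series" means these few. Any claim that something is new, unique, unknown or untested is made for them only; others in the source may bear on it.

compound 1, `Nc1ccc(C(=O)NCCCOc2cccc(CN3CCCCC3)c2)cc1`: 6.82
compound 2, `N#CN/C(=N\CCNC(=O)c1ccccc1[N+](=O)[O-])NCCCCOc1cccc(CN2CCCCC2)c1`: 7.52
compound 3, `N#CN/C(=N\CCNC(=O)CCc1ccccc1)NCCCOc1cccc(CN2CCCCC2)c1`: 6.27

All three were measured in a functional assay on cardiac atrium for antagonist activity at histamine H2 receptor (Cavia porcellus); a lower number here means a less potent compound, a higher number a more potent compound, by a factor of ten per unit of this negative logarithm. Compound 2 stands highest of the three numbers; compound 1 lies below it beyond the scatter, and compound 3 lies further below it, also beyond the scatter. Compound 4, `N#CN/C(=N\CCNS(=O)(=O)c1ccccc1)NCCCCOc1cccc(CN2CCCCC2)c1`, differs from compound 2 in one place: phenylsulfonyl in place of (2-nitrophenyl)carbonyl on an amine nitrogen. Cut one bond further out, the change reads ((2-nitrophenyl)carbonyl)amino to (phenylsulfonyl)amino. Among the compounds with values here, no pair of measured compounds differs in this way, so no measured step guides the expectation. The expected step in this assay is a number 0.52 log units lower from compound 2 to compound 4 (beyond the scatter), a modest loss rather than none. Compound 4 is therefore estimated at 7, with a range from 6.3 to 7.7.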

Compound 4, negative logarithm of the antagonist equilibrium constant: 7.28
Compound 4: the middle estimate sits 0.28 log units below what was measured, within the range that was stated.
By their numbers in this assay, from the lowest: compound 3; then compound 1; then compounds 4 and 2 (each within the scatter of the next).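

In this assay, phenylsulfonyl in place of (2-nitrophenyl)carbonyl on this amine nitrogen gives a number 0.24 log units lower from compound 2 to compound 4 (within the scatter) and so leaves the number essentially unchanged. This position therefore tolerates a sulfonyl link with an unsubstituted phenyl ring as well as a carbonyl link with a nitro-bearing one. No supporting data bear on why the two groups match.

The change swaps the link and removes the nitro group together, so the two contributions stay unseparated. Open, as far as these compounds go, is how a plain benzoyl group, a methylsulfonyl group or a free amine would read at this nitrogen.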